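The compounds below may be only part of what the source reports. "The series", "measured", "known", "first", "only" and "open" are said of these compounds alone.

Of the compounds shown here, three with a shared propanoic acid chain have been tested in an assay for displacement of a labelled ligand from protein deacetylase HDAC6 (Homo sapiens), read by fluorescence polarization, with a stated time of 10 min; a lower number here means a stronger inhibitor, a higher number a weaker inhibitor. Compound 1 `O=C(O)CCc1nc2cc(Cl)ccc2s1` gives 55000 nM. Compound 3 `Cn1c(=O)c(CCC(=O)O)nc2ccccc21` gives 70000 nM. Compound 2 `O=C(O)CCc1nc2ccccc2nc1OCCOc1ccccn1` gives 110000 nM; its number is the highest of the three, yet the gap to compound 3 and the gap to compound 1 both sit within the usual scatter of this assay, so the three numbers cannot be told apart with confidence. All three are weak inhibitors.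

Compound 4 `O=C(O)CCc1nc2ccccc2nc1OCc1cccs1` has not yet been measured. It differs from compound 2 in one place: thiophen-2-yl in place of ((pyridin-2-yl)oxy)methyl on a saturated chain carbon bound to an oxygen on an aromatic ring. Among the measured compounds shown here, no step between two measured compounds of this set involves a change of this kind, so there is no measured guide to its effect. Since every compound here gives a weak number and the differences among them are within the scatter, the expected step from compound 2 to compound 4 is a 1.4-fold lower number from compound 2 to compound 4 (0.14 log units; within the scatter), that is, none beyond the scatter in either direction. Compound 4 is estimated to give 80000 nM in this assay, with a range from 30000 nM to 250000 nM.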

Compound 4, half-maximal inhibitory concentration: "not active" (no number reported)
For compound 4 the study gives words and no number; there is nothing to compare the estimate with.
By their numbers in this assay, from the lowest: compounds 1, 3 and 2 (each within the scatter of the next).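

Among the compounds shown here, compound 4 is described only in words, as "not active", in this assay and has no number, so no step from compound 2 to compound 4 can be read. No available evidence bears on this result. From the compounds shown here alone, whether thiophen-2-yl changes inhibition relative to ((pyridin-2-yl)oxy)methyl remains open.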